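This account rests on a few compounds, and the source may have more. Where it says the series, first, only, none or still open, it means among the compounds named here.

Working notes on the series. Compound 1, `Fc1ccc(Nc2cc3[nH]c(-c4cccc(C(F)(F)F)c4)nc3cn2)nc1`, was run in a physicochemical assay for solubility, using the shake flask method, in simulated intestinal fluid, measured as kinetic solubility, with a stated time of 20 h, at pH 6.5 (on this read-out lower numbers stand for lower solubility and higher numbers for higher solubility), and returned only a limit of the assay, >= 50000 nM, not a number. Compound 2, `N#Cc1ccc(Nc2cc3[nH]c(-c4cccc(C(F)(F)F)c4)nc3cn2)nc1`, in this assay likewise sits at a limit, >= 50000 nM. Compound 3, `FC(F)(F)c1ccc(Nc2cc3[nH]c(-c4cccc(C(F)(F)F)c4)nc3cn2)nc1`, in this assay also gives a limit, >= 50000 nM. Compound 3 therefore stands at the same limit as the other two measured compounds, and the three steps among them cannot be sized: a step that the two limits leave unreadable from compound 1 to compound 2, a step that the two limits leave unreadable from compound 1 to compound 3 and a step that the two limits leave unreadable from compound 2 to compound 3. This follows from the limit of >= 50000 nM in this assay, at which 3 of the 3 values shown sit. Compound 4, `O=C(O)c1ccnc(Nc2cc3[nH]c(-c4cccc(C(F)(F)F)c4)nc3cn2)c1`, is not yet measured; it differs from compound 3 by 4-carboxypyridin-2-yl in place of 5-(trifluoromethyl)pyridin-2-yl on a nitrogen on an aromatic ring. Among the compounds with values here, the three measured steps each exchange the group on this same nitrogen and none of them can be read in size, so they give no scale for the present change; they show only that every variation at this position so far has stayed at the limit. Within the data shown here, the step from compound 3 to compound 4 is thus expected to be a number no higher from compound 3 to compound 4 (the limit leaves the size open), that is, no step readable against the limit. Compound 4 is estimated at 50000 nM in this assay, within 25000 nM to 100000 nM, most likely reported again as a limit rather than a number.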

Compound 4, solubility: 60000 nM
Compound 4: middle estimate off by 1.2-fold (0.08 log units), on the low side, and the stated range covers the measured number.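

No step from compound 1, compound 2 or compound 3 to compound 4 can be read in this assay, because those three compounds give only a limit of the assay: the limit of >= 50000 nM in this assay, at which 3 of the 4 values shown sit.

The compounds shown leave open how the solubility of compound 1, compound 2 and compound 3 actually compares with that of compound 4.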